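This account rests on a few compounds, and the source may have more. Where it says the series, first, only, none or still open, it means among the compounds named here.

Measured compounds: compound 1, `CC(C)=CCC/C(C)=C/CC/C(C)=C/C(=O)NC(=N)N`, and compound 2, `CC(C)=CC(=O)NC(=N)N`.

In a functional assay on SK-MEL-28 cells (Homo sapiens) for inhibition, read by MTT assay, with a stated time of 72 h (a higher number here means a weaker inhibitor of growth, a lower number a stronger inhibitor of growth), compound 1 gives 20100 nM, the only number shown for the pair. For compound 2 the same assay reports only a limit, > 100000 nM, which is the limit of > 100000 nM in this assay, at which 1 of the 2 values shown sits.

Compound 3, `CC(C)=CCC/C(C)=C/CC/C(C)=C/C(=O)NC(=N)NC(=O)C=C(C)C`, has not been measured; it differs from compound 1 by (2-methylprop-1-en-1-yl)carbonyl in place of hydrogen on an amine nitrogen. No step between measured compounds is shown, so in this assay a change no larger than the scatter, tending if anything toward stronger inhibition, is expected: a 1.3-fold lower number from compound 1 to compound 3 (0.13 log units; within the scatter). Compound 3 is estimated at 15000 nM, within 5000 nM to 50000 nM.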

Compound 3, concentration for 50% growth inhibition: 24200 nM
For compound 3 the middle estimate is 1.6-fold (0.21 log units) below the measured one; measured number inside the range.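

In this assay, (2-methylprop-1-en-1-yl)carbonyl in place of hydrogen on the amine nitrogen gives a 1.2-fold higher number from compound 1 to compound 3 (0.08 log units; within the scatter). The earlier compounds shown here carried only hydrogen on this nitrogen, whereas this result shows that the nitrogen can bear this carbonyl group with no change in growth inhibition beyond the scatter. Nothing measured here accounts for this step.

On these data alone, whether an acetyl, a benzoyl or a carbonyl group carrying an amine would behave alike on this nitrogen remains open. So does the part played by the double bond of the entering group, which a saturated 3-methylbutanoyl group would test.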